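Urea aryl swap in the diaryl ether series

The source may report more compounds than this note shows. Statements on the series, on what has been measured and on what is new or still open speak of the compounds shown alone.

Working notes on the series. Compound 2 `CN(C)CCn1cnnc1-c1cc(Oc2ccc(NC(=O)Nc3ccc(Cl)c(C(F)(F)F)c3)cc2F)ccn1` is the reference for this step. Among the measured compounds shown here, in an ADME assay on WI-38 cells (Homo sapiens) for cytotoxicity, read by MTT assay, with a stated time of 72 h (a lower number here means a stronger inhibitor, a higher number a weaker inhibitor), compound 2 gives 3760 nM, the lowest of the two numbers known so far. For the measured compounds named here, its nearest companion, compound 1 `Cn1ncnc1-c1cc(Oc2ccc(NC(=O)Nc3cccc(C(F)(F)F)c3)cc2F)ccn1`, gives 22400 nM in this assay, a gap beyond the scatter; the two differ in more than one place, so no single step is read from that pair.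

Compound 3 `CN(C)CCn1cnnc1-c1cc(Oc2ccc(NC(=O)Nc3ccccc3C(F)(F)F)cc2F)ccn1` is not yet measured in this assay. It differs from compound 2 by 2-(trifluoromethyl)phenyl in place of 4-chloro-3-(trifluoromethyl)phenyl on an amide-type nitrogen. Going by the values given here, no measured pair shows this change on its own, so the expected step in this assay rests on the standing of compound 2 alone. Expectation: a move toward a higher number, of moderate size, a 2.4-fold higher number from compound 2 to compound 3 (0.38 log units; beyond the scatter), since the measured numbers of compound 1 and compound 2 bound the range seen so far. For compound 3 the estimated value in this assay is 9000 nM, with a range from 3000 nM to 27000 nM.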

Compound 3, half-maximal inhibitory concentration: > 50000 nM
Compound 3 was reported as a limit; the forecaster's own chance of this, stated with the estimate: 10%; at least 5.5-fold (0.74 log units) between middle value and limit.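

In this assay, compound 3 is reported only as a limit, > 50000 nM, and not as a number. Among the compounds shown here, the change to 2-(trifluoromethyl)phenyl in place of 4-chloro-3-(trifluoromethyl)phenyl on the amide-type nitrogen gives the first single-place step, an at least 13-fold higher number from compound 2 to compound 3 (1.12 log units; beyond the scatter). The aryl group at this position can therefore shift the read-out strongly on its own, while the full size of the step remains unknown: the limit of > 50000 nM in this assay, at which 1 of the 3 values shown sits.

This step combines the loss of the chlorine with a different placement of the trifluoromethyl group, and the compounds shown do not separate the two. Also open, going by these compounds, is how this position responds to an aryl group carrying a nitrile or an amine, and whether any such group brings the value back toward that of compound 2, 3760 nM.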